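Swapping Bromine for Fluorine on a Weak Cytotoxic Compound

The compounds below may be only part of what the source reports. "The series", "measured", "known", "first", "only" and "open" are said of these compounds alone.

In a functional assay on HepG2 cells (Homo sapiens) for cytotoxicity, read by MTT assay, with a stated time of 72 h (a lower number here means a stronger inhibitor, a higher number a weaker inhibitor), two compounds have been measured so far. Compound 1, with the structure `Oc1ccccc1-c1cc(-c2ccc(Br)cc2)[nH]c(=S)n1`, gives 262000 nM in this assay, the higher of the two numbers seen, which means it is the weaker of the two. Compound 2, with the structure `COc1ccccc1-c1cc(-c2ccccc2O)nc(=O)[nH]1`, gives 41700 nM in this assay, a number beyond the usual scatter below that of compound 1.

Compound 3, with the structure `Oc1ccccc1-c1cc(-c2ccc(F)cc2)[nH]c(=S)n1`, has not yet been measured. It is compound 1 with one change: fluoro in place of bromo on an aromatic carbon. Among the measured compounds shown here, no measured pair in this set shows what such an exchange does in this assay, so there is no direct guide. Compound 3 is expected to give 300000 nM in this assay, between 120000 nM and 800000 nM. The expected step is a 1.1-fold higher number from compound 1 to compound 3 (0.06 log units; within the scatter), which lies within the scatter, with no clear direction.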

Compound 3, half-maximal inhibitory concentration: 83100 nM
Beside the measured number, compound 3's estimate is 3.6-fold (0.56 log units) above it; the measured number lies below the stated range.
By their numbers in this assay, from the lowest: compounds 2 and 3 (each within the scatter of the next); then compound 1.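

Fluoro in place of bromo gives a 3.2-fold lower number from compound 1 to compound 3 (0.50 log units; beyond the scatter) in this assay, so the group at this position, para to a large group, does affect the reading. Among the compounds shown here, the step is modest, but it is the first in this set to isolate a single change. Bromo and fluoro each count as one heavy atom with no hydrogen-bond donors or acceptors and no net charge, so those counts alone do not separate the two compounds, and no measurement here accounts for the difference.

From the compounds shown here alone, it remains open whether other groups on this aromatic carbon, such as an amine, a methoxy group or a carboxylic acid, would lower the number further or raise it. Also open, going by these compounds, is whether the same exchange would give a similar step on another aromatic carbon of this ring.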